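Swapping Methoxy for Fluoro in an Inactive Series

A few compounds are considered here, and "the series" means these few. Any claim that something is new, unique, unknown or untested is made for them only; others in the source may bear on it.

Compound 1 `C=C1C[C@]23C[C@@]1(O)CC[C@H]2c1ccc(OS(=O)(=O)c2ccc(C)cc2)c(C)c1[C@@H]3Cn1cc(-c2ccc(OC)cc2)nn1` carries a methoxyphenyl group on its triazole arm. In a functional assay on HL-60 cells (Homo sapiens) for cytotoxicity, read by MTT assay, with a stated time of 4 days (a higher number here means a weaker inhibitor, a lower number a stronger inhibitor), compound 1 gives > 20000 nM, which is a limit of the assay and not a measured number. Compound 2 `C=C1C[C@]23C[C@@]1(O)CC[C@H]2c1ccc(O)c(C)c1[C@@H]3Cn1cc(-c2ccc(OC)cc2)nn1` replaces the tosyl group of compound 1 with a free hydroxyl, and in this assay compound 2 gives > 20000 nM, again a limit. The step that the two limits leave unreadable from compound 1 to compound 2 therefore cannot be read in either direction. Compound 3 `Cc1ccc(S(=O)(=O)Oc2ccc3c(c2C)[C@H](Cn2cc(-c4ccc(Br)cc4)nn2)[C@@]24CC(=O)[C@@](C)(CC[C@@H]32)C4)cc1`, a related ketone bearing a bromophenyl group, gives > 20000 nM in this assay, once more a limit. Within the data shown here, every measured value here is the limit of > 20000 nM in this assay, at which 3 of the 3 values shown sit, so no step between them can be sized.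

Compound 4 `C=C1C[C@]23C[C@@]1(O)CC[C@H]2c1ccc(OS(=O)(=O)c2ccc(C)cc2)c(C)c1[C@@H]3Cn1cc(-c2ccc(F)cc2)nn1` is compound 1 with one change: fluoro in place of methoxy on an aromatic carbon. Among the measured compounds shown here, no measured step touches this change. With compound 1 sitting at > 20000 nM, compound 4 is expected to stay at the limit as well, and the step that the limit leaves unreadable from compound 1 to compound 4 is expected to show nothing beyond the scatter. Compound 4 is expected to give 30000 nM in this assay, within a range from 12000 nM to 80000 nM.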

Compound 4, half-maximal inhibitory concentration: > 20000 nM
Compound 4: no number, only a limit; the forecaster's own chance of this, stated with the estimate: 80%; the middle value is on the limit's open side.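

In this assay compound 4 gives > 20000 nM, which is a limit and not a number. No step can be read between compound 1 and compound 4, since both sit at the same limit: the limit of > 20000 nM in this assay, at which 4 of the 4 values shown sit.

The compounds shown leave open whether fluoro and methoxy differ at all in this assay.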